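A few compounds are considered here, and "the series" means these few. Any claim that something is new, unique, unknown or untested is made for them only; others in the source may bear on it.

Of the compounds shown here, three have so far been measured in an assay on HEK293 cells for displacement of a labelled ligand from adenosine receptor A2b (Homo sapiens), read by scintillation counting, with a stated time of 30 min, tested at 10 uM; a lower number here means less inhibition, a higher number more inhibition at the concentration tested (going by the name of the read-out). Compound 1 `COc1cccc2cc(C(=O)NCC(=O)O)c(=O)oc12` gives 35% in this assay. Compound 2 `COc1cccc2cc(C(=O)Nc3c(C#N)ncn3-c3ccccc3)c(=N)oc12`, which carries a different core, gives 9% in this assay. Compound 3 `COc1ccc(-n2cnc(C#N)c2NC(=O)c2cc3cccc(OC)c3oc2=N)cc1` gives 5% in this assay, the lowest of the three numbers, though its neighbour compound 2 sits close: the step of a number 4 percentage points lower from compound 2 to compound 3 (within the scatter) lies within the scatter, so no order between compound 2 and compound 3 can be claimed. Compound 1 stands well above both, beyond the scatter.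

Compound 4 `COc1cccc2cc(C(=O)Nc3c(C#N)ncn3-c3ccc(C#N)cc3)c(=N)oc12` has not yet been measured in this assay. It differs from compound 3 in a single place: cyano in place of methoxy on an aromatic carbon. Read one bond further out, the 4-methoxyphenyl of compound 3 becomes a 4-cyanophenyl.

For the measured compounds named here, only one measured step touches this position. Putting the methoxy onto the bare ring, a number 4 percentage points lower from compound 2 to compound 3 (within the scatter), stayed within the scatter. Going by the values given here, no measured compound carries a cyano at this position, so the swap from methoxy to cyano has no direct precedent, and the expectation is a step no larger than the scatter.

Compound 4 is therefore expected to give about 8% in this assay, somewhere between 0% and 22%. The expected step is a number 3 percentage points higher from compound 3 to compound 4 (within the scatter), a change inside the scatter.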

Compound 4, a percentage reported as inhibition, at one concentration (the size of the read-out at that concentration, not a potency): 10%
Compound 4: middle estimate off by 2 percentage points, on the low side; measured number inside the range.
By their numbers in this assay, from the lowest: compounds 3, 2 and 4 (each within the scatter of the next); then compound 1.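

This position now has a direct comparison between two different groups: the swap of methoxy for cyano on the aromatic carbon para to a large group gives a number 5 percentage points higher from compound 3 to compound 4 (within the scatter) in this assay and does not separate the two compounds. Set against the bare ring, the cyano group gives a number 1 percentage points higher from compound 2 to compound 4 (within the scatter) as its step, so hydrogen, methoxy and cyano at this carbon now all read the same within the scatter, and no order among compound 2, compound 3 and compound 4 can be claimed. The result therefore widens the earlier single observation on methoxy to a second group at this position, but nothing measured here explains why these three compounds cannot be told apart.

On these data alone, only these three groups have been seen at this carbon, so it remains open whether an amine, a carboxylic acid or a longer chain such as butoxy there would move the number beyond the scatter. Also open, as far as these compounds go, is whether a methoxy or cyano group on a different carbon of this ring would behave as it does here.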